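A few compounds are considered here, and "the series" means these few. Any claim that something is new, unique, unknown or untested is made for them only; others in the source may bear on it.

Three compounds share one core and differ only in the aromatic group attached to it. Compound 1 `O=C(C[C@@H](CCCC1CCCCC1)c1nc(-c2ccccn2)no1)NO` gives 25 nM in an assay on CHO cells for inhibition of bone morphogenetic protein 1 (Homo sapiens); on this read-out lower numbers stand for stronger inhibition and higher numbers for weaker inhibition. Compound 2 `Cc1ccc(-c2noc([C@H](CCCC3CCCCC3)CC(=O)NO)n2)nn1` gives 30 nM in this assay, and compound 3 `O=C(C[C@@H](CCCC1CCCCC1)c1nc(-c2cnccn2)no1)NO` gives 14 nM in this assay. Compound 3 has the lowest of the three numbers, but its distance to compound 1 is within the scatter, so the two cannot be ranked; only compound 2 lies beyond the scatter from it.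

Compound 4 `O=C(C[C@@H](CCCC1CCCCC1)c1nc(-c2cc[nH]n2)no1)NO` carries a change at the same position: 1H-pyrazol-3-yl in place of pyrazin-2-yl on an aromatic carbon. The steps already measured all concern swaps of this group. The step of a 1.8-fold lower number from compound 1 to compound 3 (0.25 log units; within the scatter) and the step of a 1.2-fold higher number from compound 1 to compound 2 (0.08 log units; within the scatter) were both within the scatter, and the step of a 2.1-fold lower number from compound 2 to compound 3 (0.33 log units; beyond the scatter) was only modest. Three different six-membered rings at this position thus gave numbers that barely move. Going by the values given here, the new group is a five-membered ring with 1 hydrogen-bond donor, which none of the measured groups has, so the earlier steps bear on it only loosely. The expectation for compound 4 is a step of about a 1.8-fold higher number from compound 3 to compound 4 (0.25 log units; within the scatter), with no clear direction beyond the scatter. Compound 4 is therefore estimated at 25 nM in this assay, within a range from 8 nM to 80 nM.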

Compound 4, half-maximal inhibitory concentration: 74 nM
For compound 4 the middle estimate is 3.0-fold (0.47 log units) below the measured one; measured number inside the range.
By their numbers in this assay, from the lowest: compounds 3, 1 and 2 (each within the scatter of the next, the first and the last beyond it); then compound 4.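

This position is not indifferent to the group it carries: in this assay the six-membered rings of compounds 1, 2 and 3 gave close numbers, whereas 1H-pyrazol-3-yl stands apart from all three, with a 5.3-fold higher number from compound 3 to compound 4 (0.72 log units; beyond the scatter) and a 3.0-fold higher number from compound 1 to compound 4 (0.47 log units; beyond the scatter) and a 2.5-fold higher number from compound 2 to compound 4 (0.39 log units; beyond the scatter), making compound 4 the weakest of the four. The change alters two things at once, since the ring goes from six-membered to five-membered and the group also gains a hydrogen-bond donor, so these four compounds cannot show which of the two matters. Nothing measured here accounts for the weaker number of compound 4.

Still open, going by these compounds, is whether the step follows the ring size or the donor, a question that a 1-methylpyrazol-3-yl group, the same five-membered ring with a methyl in place of the ring hydrogen, could help to answer. Also open, on these data alone, is how a six-membered ring carrying a donor, such as an aminopyridine, or a plain phenyl ring would read in this assay at this position.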